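The source may hold more compounds than are shown below. What is called first, only, known or untested is meant among the compounds shown, and "the series" means these compounds.

Measured compounds:
Compound 1 `Cc1cc(OC[C@@H]2CN(C)c3ccccc3O2)ccc1C(=O)Nc1cccc(CC(=O)O)c1C`: 28 nM
Compound 2 `Cc1cc(OC[C@@H]2CN(C)c3ccccc3O2)ccc1C(=O)Nc1cc(CC(=O)O)ccc1Cl`: "not determined" (no result reported)
Compound 3 `Cc1cc(OC[C@@H]2CN(C)c3ccccc3O2)ccc1C(=O)Nc1cc(F)cc(CC(=O)O)c1`: 5.6 nM

Three compounds share one core and differ only in the ring that sits on the amide-type nitrogen. In a functional assay on CHO cells for antagonist activity at prostaglandin D2 receptor (Mus musculus), read by cAMP accumulation (on this read-out lower numbers stand for stronger inhibition and higher numbers for weaker inhibition), compound 1 gives 28 nM. For compound 2 the result in this assay is "not determined" (no result reported). In this assay, among the measured compounds shown here, compound 3 gives 5.6 nM, the lowest of the two numbers available, and the only measured step, a 5.0-fold lower number from compound 1 to compound 3 (0.70 log units; beyond the scatter), separates it from compound 1.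

Compound 4 `Cc1cc(OC[C@@H]2CN(C)c3ccccc3O2)ccc1C(=O)Nc1ccc(F)c(CC(=O)O)c1` has not yet been measured. It differs from compound 3 by 3-(carboxymethyl)-4-fluorophenyl in place of 3-(carboxymethyl)-5-fluorophenyl on an amide-type nitrogen; the two have the same atoms, joined differently, so only the position of the fluorine on that ring changes. For the measured compounds named here, no measured step matches this kind of change: the one step known moves from a ring bearing a methyl group to a ring bearing a fluorine, not a fluorine from one place to another, so it gives only indirect guidance. Compound 3 is expected to keep most of its potency in compound 4, with a shift of modest size at most, more likely towards a somewhat higher number. This amounts to an expected step of a 1.8-fold higher number from compound 3 to compound 4 (0.25 log units; within the scatter). Compound 4 is therefore estimated at 10 nM, within a range from 3 nM to 35 nM.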

Compound 4, half-maximal inhibitory concentration: 1.2 nM
Estimate against measurement, compound 4: 8.3-fold (0.92 log units) above; measured number outside the range, below it.
By their numbers in this assay, from the lowest: compound 4; then compound 3; then compound 1.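

Moving the fluorine alone, with no atom gained or lost, gives a 4.7-fold lower number from compound 3 to compound 4 (0.67 log units; beyond the scatter) in this assay and shows that the place of this one atom on the ring matters on its own. The earlier step could not show this, since it exchanged a ring bearing a methyl group for a ring bearing a fluorine and so changed the group and its place together. Against the 3-(carboxymethyl)-2-methylphenyl ring, the 3-(carboxymethyl)-4-fluorophenyl ring gives a 23-fold lower number from compound 1 to compound 4 (1.37 log units; beyond the scatter) with the shared core unchanged, and no measurement here bears on the reason for these differences.

Going by these compounds, it remains open whether a methoxy group or a nitrile, set where the fluorine sits in 3-(carboxymethyl)-4-fluorophenyl, would give a number as low as that of fluorine. On these data alone, it is also open whether a longer chain carrying the carboxylic acid, in place of the carboxymethyl group, would keep the number of compound 4 or lose it.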